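The source may report more compounds than this note shows. Statements on the series, on what has been measured and on what is new or still open speak of the compounds shown alone.

Compound 2 `CN1CCN(CCNCc2cn(-c3ccc(C(F)(F)F)cc3)nc2-c2ccc(C(F)(F)F)cc2)CC1` carries the only definite figure in an ADME assay on Huh-7 cells (Homo sapiens) for cytotoxicity; a higher number here means that more compound is tolerated, a lower number that less compound is tolerated: compound 2 gives 1500 nM. Compound 1 `Cc1ccccc1-c1nn(-c2ccc(F)cc2F)cc1CNCCN1CCN(C)CC1` returns a limit of the assay rather than a number, > 20000 nM (the limit of > 20000 nM in this assay, at which 1 of the 2 values shown sits). Compound 3 `CN1CCN(CCNCc2cn(-c3ccc(F)cc3F)nc2-c2ccc(C(F)(F)F)cc2)CC1` is unmeasured; it differs from compound 2 in one place, (2,4-difluorophenyl in place of 4-(trifluoromethyl)phenyl on an aromatic nitrogen). Among the measured compounds shown here, no measured pair differs in a single place, so no measured step can be quoted for this change. In this assay a shift toward more tolerated compound is expected, a 3.3-fold higher number from compound 2 to compound 3 (0.52 log units; beyond the scatter), beyond the usual scatter. Compound 3 is estimated at 5000 nM, with a range from 1500 nM to 20000 nM.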

Compound 3, half-maximal cytotoxic concentration: 20000 nM
Estimate against measurement, compound 3: 4.0-fold (0.60 log units) below, within the range that was stated.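

On an aromatic nitrogen, the series now has its first measured single change: in this assay, 2,4-difluorophenyl in place of 4-(trifluoromethyl)phenyl gives a 13-fold higher number from compound 2 to compound 3 (1.12 log units; beyond the scatter). This group alone moves the read-out substantially while 4-(trifluoromethyl)phenyl stays on the aromatic carbon. In this assay, 4-(trifluoromethyl)phenyl in place of 2-methylphenyl on an aromatic carbon gives a number no higher from compound 1 to compound 3 (the limit leaves the size open). The size of this step cannot be read because compound 1 returns a limit of the assay, not a number: the limit of > 20000 nM in this assay, at which 1 of the 3 values shown sits.

Still open, on these data alone, is how unsubstituted phenyl, 4-fluorophenyl or 4-methoxyphenyl would read on that aromatic nitrogen. Also open, as far as these compounds go, is whether the step holds with 2-methylphenyl on the aromatic carbon.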